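Removing the Thioester Chain from Compound 2

The source may report more compounds than this note shows. Statements on the series, on what has been measured and on what is new or still open speak of the compounds shown alone.

In a functional assay on T-24 cells (Homo sapiens) for antiproliferative activity, read by sulforhodamine B assay, with a stated time of 72 h (on this read-out higher numbers stand for weaker inhibition and lower numbers for stronger inhibition), compound 1 (`C=CCOC(=O)C1=C2C(=NC1=O)c1cccc3cccc2c13`) gives 3900 nM as its result, while compound 2 (`C=CCSc1ccc2c3c(cccc13)C1=NC(=O)C(C(=O)OCC(=O)SCCC)=C12`) gives 71800 nM and so has the higher number of the two, with a gap beyond the usual scatter. Compound 3 (`C=CCOC(=O)C1=C2C(=NC1=O)c1cccc3c(SCC=C)ccc2c13`) has not yet been measured. The structural change on going to it is vinyl in place of (propylsulfanyl)carbonyl on a saturated chain carbon bound to an oxygen next to a carbonyl group and, cut one bond further out, it reads as (((propylsulfanyl)carbonyl)methoxy)carbonyl to allyloxycarbonyl. For the measured compounds named here, no measured step of this kind exists, so the expectation rests on compound 1 (3900 nM), which also carries allyloxycarbonyl. In this assay the estimated change is a 9.0-fold lower number from compound 2 to compound 3 (0.95 log units; beyond the scatter), a clear move towards stronger inhibition. For compound 3 the expected value is 8000 nM, with an estimated range of 2000 nM to 30000 nM.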

Compound 3, half-maximal inhibitory concentration: 6600 nM
The estimate for compound 3 lay 1.2-fold (0.08 log units) above the measured number, and the stated range covers the measured number.
By their numbers in this assay, from the lowest: compounds 1 and 3 (each within the scatter of the next); then compound 2.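

In this assay the large step lies in the ester chain: vinyl in place of (propylsulfanyl)carbonyl gives an 11-fold lower number from compound 2 to compound 3 (1.04 log units; beyond the scatter) and moves the result towards stronger inhibition. Allylsulfanyl in place of hydrogen on an aromatic carbon gives a 1.7-fold higher number from compound 1 to compound 3 (0.23 log units; within the scatter) and so stays within the usual scatter. Taken together, these two steps tie the weak result of compound 2 to its (propylsulfanyl)carbonyl group, not to its allylsulfanyl group, a link that the earlier pair, differing in two places, could not show.

From the compounds shown here alone, it remains open whether a carboxylic acid or a longer chain at the end of the ester would match allyloxycarbonyl, and whether an amine on the aromatic carbon would stay within the scatter as allylsulfanyl does. Nothing measured here gives a reason for either step.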